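The compounds below may be only part of what the source reports. "The series", "measured", "known", "first", "only" and "open" are said of these compounds alone.

Measured compounds:
- compound 2 `Cc1cc(C(=O)O)ccc1OCCCCOc1ccc(C(=O)CC(C)C)c(O)c1C`: 1850 nM
- compound 3 `CCCC(=O)c1ccc(OCCCCOc2ccc(F)c(C(=O)O)c2)c(C)c1O`: 438 nM
- compound 1 `COc1cc(C(=O)O)ccc1OCCCCOc1ccc(C(=O)C(C)C)c(O)c1C`: "not determined" (no result reported)

In an assay on HEK293 cells for positive allosteric modulation of metabotropic glutamate receptor 3 (Rattus norvegicus), read by thallium flux, with a stated time of 2.5 min (a higher number here means that more compound is needed for the effect, a lower number that less compound is needed), compound 2 gives 1850 nM, the higher of the two numbers; compound 3 gives 438 nM, and the gap between them is beyond the scatter. For the measured compounds named here, compound 1 carries a methoxy group and a two-carbon ketone chain but has no number, so no step joins it to compound 2.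

Compound 4 `COc1cc(C(=O)O)ccc1OCCCCOc1ccc(C(=O)CC(C)C)c(O)c1C` is compound 2 with methoxy in place of methyl on an aromatic carbon. Going by the values given here, no measured pair shows this change on its own. Among the compounds with values here, with the gap between compound 2 and compound 3 as the only guide, a small step in either direction, not clearly beyond the scatter, is expected; compound 4 is estimated at 1500 nM, within 500 nM to 4500 nM, which means an expected step of a 1.2-fold lower number from compound 2 to compound 4 (0.09 log units; within the scatter).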

Compound 4, half-maximal effective concentration: 614 nM
Estimate against measurement, compound 4: 2.4-fold (0.39 log units) above; measured number inside the range.
By their numbers in this assay, from the lowest: compounds 3 and 4 (each within the scatter of the next); then compound 2.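

In this assay, for the compounds shown here, this is the first comparison that changes one place only: methoxy in place of methyl on this aromatic carbon gives a 3.0-fold lower number from compound 2 to compound 4 (0.48 log units; beyond the scatter) and the position, ortho to a large group and meta to a carboxy group, is thus sensitive to the change. The swap adds one hydrogen-bond acceptor by count and comes with a modest move to a lower number. Nothing at hand accounts for the step.

Open, from the compounds shown here alone, is how an ethoxy group, an amine or a chloro group would behave on this carbon. Also open, going by these compounds, is whether the step carries over to a shorter ketone chain.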